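Series notes: aryl fluorine removed, compound 3 to compound 4

The compounds below may be only part of what the source reports. "The series", "measured", "known", "first", "only" and "open" are said of these compounds alone.

Measured so far in a functional assay on the whole organism (strain Wistar) with Rattus norvegicus as the target, with a stated time of 1 h; a higher number here means that more compound is needed for the effect, a lower number that less compound is needed:
compound 1, `Cc1ccc(-c2noc(Cn3cncn3)n2)cc1`, 76.5 mg/kg
compound 3, `Fc1cccc(-c2nc(Cn3cncn3)no2)c1`, 73.9 mg/kg
compound 2, `Clc1ccc(-c2nc(Cn3cncn3)no2)cc1`, reported only as a limit of the assay, > 100 mg/kg

Compound 3 and compound 1 give numbers that sit within the usual scatter of each other, so no order between them can be read from this assay . For compound 2 the readout is a limit, not a number, and it tells only that the dose for half-maximal effect was not reached within the tested range; the limit of > 100 mg/kg in this assay, at which 1 of the 3 values shown sits, marks where this limit sits. Among the measured compounds shown here, no two of the measured compounds differ in a single place, so no measured step is available from which to scale the next change.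

Compound 4, `c1ccc(-c2nc(Cn3cncn3)no2)cc1`, differs from compound 3 by hydrogen in place of fluoro on an aromatic carbon. With no measured step of this kind in the series, the expectation rests on the measured values alone: compound 1 and compound 3 carry different small groups on the same ring and still land within the scatter of each other, while the limit of compound 2 stands apart. The step in this assay from compound 3 to compound 4 is therefore expected to be small, a 1.1-fold higher number from compound 3 to compound 4 (0.05 log units; within the scatter), with the direction uncertain and likely inside the scatter. For compound 4 the estimate in this assay is 82 mg/kg, expected to fall between 45 mg/kg and 150 mg/kg.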

Compound 4, dose for half-maximal effect: 25.5 mg/kg
For compound 4 the middle estimate is 3.2-fold (0.51 log units) above the measured one; measured number outside the range, below it.
By their numbers in this assay, from the lowest: compound 4; then compounds 3 and 1 (each within the scatter of the next). At a limit, above all of these: compound 2.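

In this assay the series now has its first measured steps at a single place, and hydrogen in place of fluoro on the aromatic carbon gives a 2.9-fold lower number from compound 3 to compound 4 (0.46 log units; beyond the scatter). Among the compounds shown here, this modest step shows that the position meta to the large group is not indifferent to the change, which the earlier compounds, none of them a single-place pair, could not show. Hydrogen in place of chloro points the same way, with an at least 3.9-fold lower number from compound 2 to compound 4 (0.59 log units; beyond the scatter), but compound 2 is reported only as a limit of the assay, so this step has a lower bound and no exact size: the limit of > 100 mg/kg in this assay, at which 1 of the 4 values shown sits.

Both pairs agree that the compound without a halogen has the lower number, but two pairs cannot say whether this holds for halogens alone or for any group on that ring. A methoxy group, an amine or a carboxylic acid on the same aromatic carbon of the core of compound 4 would separate these readings, and fluoro at another carbon of the ring would show how far the step depends on place.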